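Replacing a Nitrile by a Hydroxamic Acid Tail

A few compounds are considered here, and "the series" means these few. Any claim that something is new, unique, unknown or untested is made for them only; others in the source may bear on it.

Measured so far:
compound 1, `CC(=O)c1ccc(OCCCCC#N)cc1O`, 0%
compound 2, `C=CCc1cc(C(C)=O)c(O)cc1OCCCCCC#N`, 41%
compound 3, `CCCc1cc(C(C)=O)c(O)cc1OCCCCC(=O)O`, 0%

Three compounds share a core carrying an acetyl group, a phenolic hydroxyl and an ether chain. In an assay on isolated protein for binding affinity to leukotriene B4 receptor 1 (Homo sapiens), tested at 1 uM (on this read-out higher numbers stand for more inhibition at the one concentration tested (going by the name of the read-out) and lower numbers for less inhibition), compound 2 gives 41%, the highest of the three numbers, and its distance from both compound 1 and compound 3 lies beyond the usual scatter. Compound 1, with a shorter chain and no allyl group, and compound 3, with a propyl group and a carboxylic acid at the end of the chain, both give no measurable inhibition.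

The step to be followed leads from compound 2 to compound 4, `C=CCc1cc(C(C)=O)c(O)cc1OCCCCCC(=O)NO`. The change is hydroxycarbamoyl in place of cyano on a saturated chain carbon, five bonds along the chain from an oxygen on an aromatic ring. The allyl group and the chain length of compound 2 are kept; only the end group is exchanged.

Among the measured compounds shown here, no measured pair shows this exchange, so its effect can only be guessed. Compound 3 shows that an acidic end group on a related compound gave nothing, but that compound also differs in the allyl group, so no clean lesson is available. A moderate decrease is expected, within or slightly beyond the scatter, as step a number 13 percentage points lower from compound 2 to compound 4 (beyond the scatter). For compound 4 the estimated value in this assay is 28%, with a range from 5% to 55%.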

Compound 4, a percentage reported as inhibition, at one concentration (the size of the read-out at that concentration, not a potency): 28%
Compound 4: middle estimate and measured number agree at the digits printed; the range from low to high includes it.
By their numbers in this assay, from the lowest: compounds 1 and 3 (each within the scatter of the next); then compound 4; then compound 2.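

The first clean test of this end group comes from exchanging cyano for hydroxycarbamoyl on a saturated chain carbon, five bonds along the chain from an oxygen on an aromatic ring, which in this assay gives a number 13 percentage points lower from compound 2 to compound 4 (beyond the scatter). The step is modest, and compound 4 still gives 28%, so at this place inhibition does not depend entirely on the nitrile and survives an exchange in which the end group grows from 2 heavy atoms to 4 and from 0 hydrogen-bond donors to 2. Nothing measured here explains why the number falls with this exchange.

As far as these compounds go, whether other end groups at this place, such as a primary amide, a methyl ester or a tetrazole, would give a number nearer to that of compound 2 or further from it remains open, as does the effect of a longer chain carrying hydroxycarbamoyl. From the compounds shown here alone, each number is also a reading at a single concentration, so how compound 2 and compound 4 would compare across a full range of concentrations remains unknown.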